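The compounds below may be only part of what the source reports. "The series", "measured", "known", "first", "only" and "open" are said of these compounds alone.

Compound 3 `CCOC(=O)c1cnc(N2CCN(Cc3cccc(F)c3)CC2)nc1Oc1c(C)cc(-c2ccc(C#N)cc2)cc1C` sits among three compounds measured in an ADME assay on MT4 cells (Homo sapiens) for cytotoxicity, read by MTT assay, with a stated time of 4 days; on this read-out lower numbers stand for higher toxicity in this test and higher numbers for lower toxicity in this test. In this assay compound 3 gives > 125000 nM, which is a limit of the assay and not a number. Compound 1 `CCOC(=O)c1cnc(N2CCN(Cc3cccc(C#N)c3)CC2)nc1Oc1c(C)cc(-c2ccc(C#N)cc2)cc1C` likewise reaches only a limit there, > 125000 nM. Compound 2 `CCOC(=O)c1cnc(N2CCN(Cc3ccc(F)cc3)CC2)nc1Oc1c(C)cc(-c2ccc(C#N)cc2)cc1C` gives > 117000 nM, again a limit. Two of the three values rest at the limit of > 125000 nM in this assay, at which 2 of the 3 values shown sit, and one at the limit of > 117000 nM in this assay, at which 1 of the 3 values shown sits, so the steps among them, a step that the two limits leave unreadable from compound 1 to compound 2, a step that the two limits leave unreadable from compound 1 to compound 3 and a step that the two limits leave unreadable from compound 2 to compound 3, cannot be read in size or direction; all that is known is that none of the three compounds showed toxicity within the tested range. Compound 4 `CCOC(=O)c1cnc(N2CCN(Cc3ccccc3F)CC2)nc1Oc1c(C)cc(-c2ccc(C#N)cc2)cc1C` differs from compound 3 in one place: 2-fluorophenyl in place of 3-fluorophenyl on a saturated chain carbon bound to an amine nitrogen in a ring. The measured steps touch the same part of the molecule, yet none of them yields a readable size, so no step beyond the scatter is expected in this assay, a number no higher from compound 3 to compound 4 (the limit leaves the size open). Compound 4 is therefore estimated at 125000 nM, within 60000 nM to 250000 nM, and most likely the assay will again report only a limit.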

Compound 4, half-maximal cytotoxic concentration: > 125000 nM
Compound 4: a limit, no number; the forecaster's own chance of this, stated with the estimate: 85%; the middle value sits exactly at the limit.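

In this assay compound 4 gives > 125000 nM, a limit of the assay and not a number. The steps from compound 1, compound 2 and compound 3 to compound 4 cannot be read in size or direction. The compounds shown leave open at what concentration any of the four would show toxicity.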